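This account rests on a few compounds, and the source may have more. Where it says the series, first, only, none or still open, it means among the compounds named here.

Measured compounds:
Compound 1 `CC1(C)[C@H]2CC[C@]1(C)N(Cc1cn(-c3ccc(F)cc3)nn1)C(=O)C2`: 500 nM
Compound 2 `CC1(C)[C@H]2CC[C@]1(C)N(Cc1cn(-c3cccc(Cl)c3)nn1)C(=O)C2`: 510 nM
Compound 3 `CC1(C)[C@H]2CC[C@]1(C)N(Cc1cn(-c3ccc(O)cc3)nn1)C(=O)C2`: 330 nM

All three were read in a functional assay on SGC-7901 cells (Homo sapiens) for inhibition, read by MTT assay, with a stated time of 24 h; on this read-out lower numbers stand for stronger inhibition and higher numbers for weaker inhibition. Compound 3 stands within the scatter of both others, with a 1.5-fold lower number from compound 2 to compound 3 (0.19 log units; within the scatter). Compound 4 `CC1(C)[C@H]2CC[C@]1(C)N(Cc1cn(-c3ccc(Cl)cc3)nn1)C(=O)C2` keeps the shared core and carries chloro in place of hydroxy on an aromatic carbon, para to a large group (chloro in place of hydroxy on an aromatic carbon). The nearest evidence is hydroxy in place of fluoro, a 1.5-fold lower number from compound 1 to compound 3 (0.18 log units; within the scatter), and 3-chlorophenyl in place of 4-fluorophenyl, a 1.0-fold higher number from compound 1 to compound 2 (0.01 log units; within the scatter). Both stayed within the scatter. No step beyond the scatter is therefore expected in this assay, the estimated change being a 1.4-fold higher number from compound 3 to compound 4 (0.13 log units; within the scatter). Compound 4 is estimated at 450 nM, with an expected range from 230 nM to 900 nM.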

Compound 4, half-maximal inhibitory concentration: 410 nM
Compound 4: the middle estimate sits 1.1-fold (0.04 log units) above what was measured, and the stated range covers the measured number.
By their numbers in this assay, from the lowest: compounds 3, 4, 1 and 2 (each within the scatter of the next).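

Within this assay, chloro in place of hydroxy on the aromatic carbon para to a large group gives a 1.2-fold higher number from compound 3 to compound 4 (0.09 log units; within the scatter), so exchanging the hydroxy, with its counted hydrogen-bond donor and acceptor, for a chloro with neither leaves the number within the scatter. Chloro in place of fluoro at this place gives a 1.2-fold lower number from compound 1 to compound 4 (0.09 log units; within the scatter), and 4-chlorophenyl in place of 3-chlorophenyl gives a 1.2-fold lower number from compound 2 to compound 4 (0.09 log units; within the scatter), so neither step moves the number beyond the scatter. No measurement shown explains this flatness.

From the compounds shown here alone, whether an amine, a carboxylic acid or a longer chain at this place would move the number beyond the scatter remains open.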